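The source may hold more compounds than are shown below. What is called first, only, known or untested is meant among the compounds shown, and "the series" means these compounds.

Three compounds share one core and differ only in the group on the aromatic ring. In a functional assay on HeLa cells (Homo sapiens) for antiproliferative activity, read by resazurin assay (on this read-out lower numbers stand for stronger inhibition and higher numbers for weaker inhibition), compound 1 `CCSC(=S)SCC(=O)c1ccc(C)cc1` gives 3980 nM, compound 2 `CCSC(=S)SCC(=O)c1ccc(Cl)cc1` gives 5010 nM and compound 3 `CCSC(=S)SCC(=O)c1ccc(OC)cc1` gives 2510 nM. Compound 3 has the lowest of the three numbers, yet its gaps to compound 1 and compound 2 both lie within the scatter. Compound 4 `CCSC(=S)SCC(=O)c1ccc(NS(C)(=O)=O)cc1` differs from compound 3 by methanesulfonamido in place of methoxy on an aromatic carbon. For the measured compounds named here, the steps that bear on this exchange are a 1.3-fold higher number from compound 1 to compound 2 (0.10 log units; within the scatter), a 1.6-fold lower number from compound 1 to compound 3 (0.20 log units; within the scatter) and a 2.0-fold lower number from compound 2 to compound 3 (0.30 log units; within the scatter), each a swap of the same aromatic group and each within the scatter. Compound 4 is therefore expected to show no step beyond the scatter, a 1.3-fold higher number from compound 3 to compound 4 (0.11 log units; within the scatter), and its estimated value is 3200 nM, between 1000 nM and 10000 nM.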

Compound 4, half-maximal inhibitory concentration: 39800 nM
For compound 4 the middle estimate is 12-fold (1.09 log units) below the measured one, and the stated range ends below it.
By their numbers in this assay, from the lowest: compounds 3, 1 and 2 (each within the scatter of the next); then compound 4.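

In this assay, the position that held methyl, chloro and methoxy within the scatter proves sensitive to what it carries: methanesulfonamido gives a 16-fold higher number from compound 3 to compound 4 (1.20 log units; beyond the scatter), along with a 7.9-fold higher number from compound 2 to compound 4 (0.90 log units; beyond the scatter) and a 10-fold higher number from compound 1 to compound 4 (1.00 log units; beyond the scatter). Unlike methoxy, the entering group brings a hydrogen-bond donor and more heavy atoms, but no data shown tie the weaker inhibition to either feature. As far as these compounds go, what stays open is which feature of methanesulfonamido goes with the higher number. An amine, an acetamido group or a methylsulfonyl group on this aromatic carbon would help separate them.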